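This account rests on a few compounds, and the source may have more. Where it says the series, first, only, none or still open, it means among the compounds named here.

Compound 1 `CC1=C(C(=O)Nc2ccc(Br)cc2)C(c2ccc(Cl)cc2Cl)N=C(SCc2ccccc2)N1` gives 24.2% in a functional assay on the whole organism (artery, strain albino) with Rattus norvegicus as the target, with a stated time of 360 min, at a dose of 10 mg/kg by the oral route; on this read-out lower numbers stand for less inhibition and higher numbers for more inhibition at the one dose given (going by the name of the read-out).
Compound 2 `CC1=C(C(=O)Nc2ccc(Br)cc2)C(c2ccc(Cl)cc2Cl)N=C(SCc2ccc(Cl)cc2)N1` gives 39.7% in this assay.

Compound 2 stands highest of the two numbers, its nearest neighbour being compound 1, the step being a number 15.5 percentage points higher from compound 1 to compound 2 (beyond the scatter). Compound 3 `CC1=C(C(=O)Nc2ccc(Br)cc2)C(c2ccc(Cl)cc2Cl)N=C(SCc2ccc(F)cc2)N1` differs from compound 2 in one place: fluoro in place of chloro on an aromatic carbon. Among the measured compounds shown here, the one measured step that bears on this change, a number 15.5 percentage points higher from compound 1 to compound 2 (beyond the scatter), was modest and lies beyond the scatter. Because a number 15.5 percentage points higher from compound 1 to compound 2 (beyond the scatter) was modest, the step from compound 2 to compound 3 is expected to be small, a number 7.7 percentage points lower from compound 2 to compound 3 (within the scatter), and may lie within the scatter. Compound 3 is therefore estimated at 32%, with a range of 20% to 44%.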

Compound 3, a percentage reported as inhibition, in the whole organism at one dose (the size of the read-out at that dose, not a potency): 40.7%
Estimate against measurement, compound 3: 8.7 percentage points below; the range from low to high includes it.
By their numbers in this assay, from the lowest: compound 1; then compounds 2 and 3 (each within the scatter of the next).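

The change from 4-chlorobenzyl to 4-fluorobenzyl gives a number 1 percentage points higher from compound 2 to compound 3 (within the scatter) in this assay, so at this place the two halogens cannot be told apart on this read-out. Fluoro in place of hydrogen gives a number 16.5 percentage points higher from compound 1 to compound 3 (beyond the scatter) and so, like chloro, stands clear of the unsubstituted compound 1, which means the gain at this carbon is not tied to chloro alone. Nothing given here bears on why the two halogens match.

Going by these compounds, what a methoxy group or an amine would give at this place remains open, as does whether a bromo group would match fluoro and chloro.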